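Swapping an amide link for a urea link

This account rests on a few compounds, and the source may have more. Where it says the series, first, only, none or still open, it means among the compounds named here.

Of the compounds shown here, two from this series have been measured in a functional assay on NCI/ADR-RES cells (Homo sapiens) for inhibition, read by sulforhodamine B assay, with a stated time of 48 h; a higher number here means a weaker inhibitor of growth, a lower number a stronger inhibitor of growth. Compound 2, with structure `COc1cc(-c2nn(-c3cccc(NC(=O)c4cccc(C(F)(F)F)c4)c3)cc2-c2ccncc2)ccc1Cl`, gives 1090 nM. Compound 1, with structure `O=C(Nc1cccc(-n2cc(-c3ccncc3)c(-c3ccc(Cl)c(O)c3)n2)c1)Nc1cccc(C(F)(F)F)c1`, gives 2140 nM; these two numbers lie within the scatter of each other, so neither can be called the stronger growth inhibitor. Compound 3, with structure `COc1cc(-c2nn(-c3cccc(NC(=O)Nc4cccc(C(F)(F)F)c4)c3)cc2-c2ccncc2)ccc1Cl`, has not yet been measured. It differs from compound 2 in one place: (3-(trifluoromethyl)phenyl)amino in place of 3-(trifluoromethyl)phenyl on a carbonyl carbon. In words, an amide link becomes a urea link while the rest of the molecule stays the same. Compound 1 already carries a urea link, and its number sits close to that of compound 2, which suggests the link itself matters little here. Compound 3 is therefore expected to give about 1500 nM, within a range from 500 nM to 4500 nM, a step of a 1.4-fold higher number from compound 2 to compound 3 (0.14 log units; within the scatter) that is expected to stay within the scatter.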

Compound 3, concentration for 50% growth inhibition: 783 nM
Compound 3: the middle estimate sits 1.9-fold (0.28 log units) above what was measured, within the range that was stated.
By their numbers in this assay, from the lowest: compounds 3, 2 and 1 (each within the scatter of the next, the first and the last beyond it).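

In this assay, the urea link on this carbonyl carbon can be told apart from the amide link by no more than the usual scatter, with a 1.4-fold lower number from compound 2 to compound 3 (0.14 log units; within the scatter), even though the change adds a nitrogen and a hydrogen-bond donor. For the compounds shown here, with the urea link held constant, the group on the oxygen on the aromatic ring can be read directly for the first time: methyl in place of hydrogen gives a 2.7-fold lower number from compound 1 to compound 3 (0.44 log units; beyond the scatter), a modest step but the only single change here beyond the scatter. Nothing available explains why this step appears.

From the compounds shown here alone, it remains open whether the methyl step would also appear with the amide link in place of the urea link. Going by these compounds, it is also open how a carbamate link, or an ethyl group on that oxygen, would read.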